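The source may hold more compounds than are shown below. What is called first, only, known or untested is meant among the compounds shown, and "the series" means these compounds.

Compound 1 `CCn1c(C(=O)NCCNC(=O)OC(C)(C)C)ccc1C(CC)(CC)c1ccc(OCS(=O)(=O)c2ccccc2)c(C)c1` carries a 2-((tert-butoxycarbonyl)amino)ethyl group on the amide-type nitrogen. In a functional assay on BXPC-3 cells (Homo sapiens) for antiproliferative activity, read by MTT assay, with a stated time of 24 h (on this read-out higher numbers stand for weaker inhibition and lower numbers for stronger inhibition), compound 1 gives only a limit, > 50000 nM, and no number. Within the data shown here, compound 2 `CCn1c(C(=O)N[C@H](CO)CCO)ccc1C(CC)(CC)c1ccc(OCS(=O)(=O)c2ccccc2)c(C)c1` bears a 3-hydroxy-1-(hydroxymethyl)propyl group in the same place, and in this assay compound 2 gives 15900 nM, the only actual number among the two values shown. The other value, that of compound 1, is a limit: the limit of > 50000 nM in this assay, at which 1 of the 2 values shown sits. The change between them reads an at least 3.1-fold lower number from compound 1 to compound 2 (0.49 log units; beyond the scatter).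

Compound 3 `CCn1c(C(=O)N[C@H](CC(=O)O)C(=O)O)ccc1C(CC)(CC)c1ccc(OCS(=O)(=O)c2ccccc2)c(C)c1` differs from compound 2 in the same place: 1,2-dicarboxyethyl in place of 3-hydroxy-1-(hydroxymethyl)propyl on an amide-type nitrogen. Among the measured compounds shown here, the only measured step that bears on this position is the one from compound 1 to compound 2, which was at least modest and ran from a limit to a number, so it shows that exchanging the group on this nitrogen can shift the read-out, but gives no firm size for a second exchange. For the measured compounds named here, no measured pair separates the 3-hydroxy-1-(hydroxymethyl)propyl group from the 1,2-dicarboxyethyl group, and no step beyond the scatter is expected in either direction. Compound 3 is therefore expected to sit near compound 2, with a 1.3-fold higher number from compound 2 to compound 3 (0.10 log units; within the scatter). The estimate for compound 3 in this assay is 20000 nM, with a range from 7000 nM to 50000 nM.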

Compound 3, half-maximal inhibitory concentration: > 50000 nM
Compound 3 gave a limit, no number; the forecaster's own chance of this, stated with the estimate: 35%; middle value at least 2.5-fold (0.39 log units) away from the limit.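

Among these compounds, until this result, the only step that could be read on the amide-type nitrogen ran towards a lower number; this exchange runs the other way, with an at least 3.1-fold higher number from compound 2 to compound 3 (0.49 log units; beyond the scatter). The 3-hydroxy-1-(hydroxymethyl)propyl and 1,2-dicarboxyethyl groups share the same counts of hydrogen-bond donors and acceptors, and neither has a ring or a net charge, so in this assay these shared counts alone do not fix the read-out at this position. Compound 2 is now the only one of the three with an actual number, and the step from compound 1 to compound 3 cannot be read, as both of these compounds rest on a limit: the limit of > 50000 nM in this assay, at which 2 of the 3 values shown sit.

The compounds shown leave open whether a group with a single carboxylic acid, or with one carboxylic acid and one hydroxyl, would stay near compound 2 or reach the limit as well. They also leave open whether a free amine, such as 2-aminoethyl, or a longer chain bearing two hydroxyl groups on this nitrogen would give a lower number than compound 2 does.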